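From diethylamino to 2-fluoroethoxy on compound 3

The compounds below may be only part of what the source reports. "The series", "measured", "known", "first", "only" and "open" are said of these compounds alone.

Measured so far in a functional assay on HCT-116 cells (Homo sapiens) for cytotoxicity, read by MTT assay, with a stated time of 48 h, in the presence of a further agent that is not named here (on this read-out lower numbers stand for an effect already at smaller amounts and higher numbers for an effect only at larger amounts of compound), are three compounds
Compound 1 `Cc1c(Cc2ccccc2)c(NNC(=O)Nc2cc(Cl)nc(Cl)c2)nc2c1cnn2C` gives 13600 nM
Compound 2 `Cn1ncc2c(-c3ccc(F)cc3)cc(NNC(=O)Nc3cc(Cl)cc(Cl)c3)nc21` gives 39100 nM
Compound 3 `CCN(CC)c1cc(NC(=O)NNc2cc(-c3ccc(F)cc3)c3cnn(C)c3n2)cc(Cl)n1` gives 29400 nM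

On these numbers, compound 3 at 29400 nM sits within the scatter of compound 2 at 39100 nM in this comparison. Compound 1 at 13600 nM has a lower number than compound 3, and that gap lies beyond the scatter.

Compound 4 `Cn1ncc2c(-c3ccc(F)cc3)cc(NNC(=O)Nc3cc(Cl)nc(OCCF)c3)nc21` has not yet been measured. It differs from compound 3 by 2-fluoroethoxy in place of diethylamino on an aromatic carbon of the six-membered aromatic ring with 1 nitrogen, next to the ring nitrogen and meta to a chloro group.

Among the measured compounds shown here, no measured pair differs in one place only, so the data give no direct guide to this change. In this assay no step beyond the scatter is expected. That expectation rests only on compound 2 at 39100 nM and compound 3 at 29400 nM lying within the scatter of each other. The estimated step of a 1.2-fold lower number from compound 3 to compound 4 (0.07 log units; within the scatter) is therefore expected to be small. For compound 4 the expected value is 25000 nM, with an estimated range from 10000 nM to 55000 nM for the measurement that follows.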

Compound 4, half-maximal effective concentration: 37200 nM
Beside the measured number, compound 4's estimate is 1.5-fold (0.17 log units) below it, and the stated range covers the measured number.
By their numbers in this assay, from the lowest: compound 1; then compounds 3, 4 and 2 (each within the scatter of the next).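

In this assay, among the compounds shown here, the first comparisons between compounds that differ in one place become possible, and 2-fluoroethoxy in place of diethylamino on an aromatic carbon next to the ring nitrogen gives a 1.3-fold higher number from compound 3 to compound 4 (0.10 log units; within the scatter) and so does not separate these two groups at this position. The second comparison reads the same way: 2-chloro-6-(2-fluoroethoxy)pyridin-4-yl in place of 3,5-dichlorophenyl on an amide-type nitrogen gives a 1.1-fold lower number from compound 2 to compound 4 (0.02 log units; within the scatter) and thus shows no step beyond the scatter for this exchange either. No measurement at hand bears on why these exchanges leave the numbers within the scatter.

From the compounds shown here alone, whether any group at this position can give a step beyond the scatter stays open, for instance an unsubstituted amine, a carboxylic acid or a longer alkoxy chain. Going by these compounds, with only these two exchanges read, it also stays open whether the chloro group that remains on the ring of compound 3 and compound 4 can be replaced without a step beyond the scatter.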